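The source may hold more compounds than are shown below. What is called first, only, known or untested is meant among the compounds shown, and "the series" means these compounds.

The measured compounds and their values:

Compound 1, `CCn1c(C(=O)N[C@@H](C)CO)ccc1C(CC)(CC)c1ccc(OCS(=O)(=O)c2ccccc2)c(C)c1`, in a functional assay on MCF7 cells (Homo sapiens) for antiproliferative activity, read by MTT assay, with a stated time of 24 h (a higher number here means a weaker inhibitor, a lower number a stronger inhibitor), gives 10800 nM.
Compound 2, `CCn1c(C(=O)NCCO)ccc1C(CC)(CC)c1ccc(OCS(=O)(=O)c2ccccc2)c(C)c1`, gives 15500 nM.
Compound 3, `CCn1c(C(=O)N[C@H](CO)CCCO)ccc1C(CC)(CC)c1ccc(OCS(=O)(=O)c2ccccc2)c(C)c1`, gives 31400 nM.

Compound 3 stands with the highest number of the three. Its separation from the others rests on a 2.9-fold higher number from compound 1 to compound 3 (0.46 log units; beyond the scatter) and on a 2.0-fold higher number from compound 2 to compound 3 (0.31 log units; beyond the scatter), both beyond the scatter and both modest, whereas a 1.4-fold higher number from compound 1 to compound 2 (0.16 log units; within the scatter) stays within the scatter, so compound 1 and compound 2 cannot be ordered against each other.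

The unmeasured compound 4, `CCn1c(C(=O)N[C@@H](CC(=O)O)C(=O)O)ccc1C(CC)(CC)c1ccc(OCS(=O)(=O)c2ccccc2)c(C)c1`, differs from compound 3 in a group of 8 heavy atoms (4 carbon, 4 oxygen; no ring) in place of a group of 7 heavy atoms (5 carbon, 2 oxygen; no ring), on an amide-type nitrogen. For the measured compounds named here, all three measured steps altered the substituent on the same amide-type nitrogen and so bear on this change, but each exchanged only hydrogen, methyl or a hydroxyalkyl chain, and none introduced a carboxylic acid; the data hold no step of that kind. The two steps that added a hydroxyalkyl chain, from compound 1 and from compound 2 to compound 3, gave modestly higher numbers. Going by the values given here, the change to compound 4 is larger than any measured one, and with no direct precedent the expected step of a 1.4-fold higher number from compound 3 to compound 4 (0.16 log units; within the scatter) is set toward a somewhat higher number with wide uncertainty. Compound 4 is therefore estimated at 45000 nM, with a range from 12000 nM to 150000 nM.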

Compound 4, half-maximal inhibitory concentration: > 50000 nM
Compound 4 was reported as a limit (the forecaster's own chance of this, stated with the estimate: 30%); at least 1.1-fold (0.04 log units) between middle value and limit.
By their numbers in this assay, from the lowest: compounds 1 and 2 (each within the scatter of the next); then compound 3. At a limit, above all of these: compound 4.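

In this assay, compound 4 is reported only as a limit and not as a number: the limit of > 50000 nM in this assay, at which 1 of the 4 values shown sits. With 1,2-dicarboxyethyl on the amide-type nitrogen, the readings against the two smaller substituents are an at least 3.2-fold higher number from compound 2 to compound 4 (0.50 log units; beyond the scatter) and an at least 4.6-fold higher number from compound 1 to compound 4 (0.66 log units; beyond the scatter), both beyond the scatter, so this position, so far probed only with hydroxyalkyl chains, now shows that a group carrying two carboxylic acids also does not bring a lower number than compounds 1 and 2 give. Against the longer hydroxyalkyl chain the reading is an at least 1.5-fold higher number from compound 3 to compound 4 (0.20 log units; that floor lies within the scatter), and because that floor lies within the scatter, compound 4 cannot yet be placed apart from compound 3, although it joins compound 3 on the weaker side of the set.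

The compounds shown leave open how far the true value of compound 4 lies beyond its limit, and whether a single carboxylic acid on this nitrogen would behave like the 1,2-dicarboxyethyl group or like the hydroxyalkyl chains. They also leave open what an amine, or a plain alkyl chain without hydroxyl, would give at this position on the shared core.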